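Replacing cyclopropyl with 2-hydroxyphenyl: expected clearance of compound 3

A few compounds are considered here, and "the series" means these few. Any claim that something is new, unique, unknown or untested is made for them only; others in the source may bear on it.

Compound 1 `Nc1ccc(S(=O)(=O)N2CCN(c3ncc(C(O)(C(F)(F)F)C(F)(F)F)cc3C3CC3)CC2)cn1` gives 38 mL.min-1.g-1 in an ADME assay (liver) for metabolic stability, with Liver microsome (Homo sapiens) as the target, using microsomes and NADPH, with a stated time of 30 min, tested at 1 uM; a lower number here means slower removal, a higher number faster removal of the compound.
Compound 2 `Nc1ccc(S(=O)(=O)N2CCN(c3ncc(C(O)(C(F)(F)F)C(F)(F)F)cc3-c3ccoc3)CC2)cn1` gives only a limit of the assay in this assay, namely < 14 mL.min-1.g-1.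

Among the compounds with values here, compound 1 is the only compound with a full number in this assay; the other value shown is a limit. Compound 3 `Nc1ccc(S(=O)(=O)N2CCN(c3ncc(C(O)(C(F)(F)F)C(F)(F)F)cc3-c3ccccc3O)CC2)cn1` differs from compound 1 by 2-hydroxyphenyl in place of cyclopropyl on an aromatic carbon. Within the data shown here, the one measured step that bears on this change, an at least 2.7-fold lower number from compound 1 to compound 2 (0.43 log units; beyond the scatter), also placed an aromatic ring where cyclopropyl stood, and it ended at the limit of < 14 mL.min-1.g-1 in this assay, at which 1 of the 2 values shown sits. A step of similar direction and at least similar size is therefore expected in this assay. Compound 3 is expected to give 16 mL.min-1.g-1, between 8 mL.min-1.g-1 and 38 mL.min-1.g-1. That estimate corresponds to an expected 2.4-fold lower number from compound 1 to compound 3 (0.38 log units; beyond the scatter).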

Compound 3, intrinsic clearance in microsomes: 22 mL.min-1.g-1
The estimate for compound 3 lay 1.4-fold (0.14 log units) below the measured number, and the stated range covers the measured number.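

In this assay, an aromatic ring at this position does not by itself bring a step beyond the scatter: 2-hydroxyphenyl in place of cyclopropyl gives a 1.7-fold lower number from compound 1 to compound 3 (0.24 log units; within the scatter). Against furan-3-yl, 2-hydroxyphenyl gives an at least 1.5-fold higher number from compound 2 to compound 3 (0.19 log units; that floor lies within the scatter), so these two aromatic rings cannot be told apart here. Compound 2 stands at a limit of the assay, not at a number: the limit of < 14 mL.min-1.g-1 in this assay, at which 1 of the 3 values shown sits. The compounds shown leave open what the hydroxyl of 2-hydroxyphenyl contributes, and whether an unsubstituted phenyl or a methoxyphenyl would read differently.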